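Swapping methyl for oxan-4-yl on the shared core

The source may report more compounds than this note shows. Statements on the series, on what has been measured and on what is new or still open speak of the compounds shown alone.

Two compounds have values in an ADME assay on microsomes from liver (Rattus norvegicus) for metabolic stability, read by LC-MS, using NADPH, with a stated time of 30 min, tested at 1 uM (on this read-out lower numbers stand for slow clearance and higher numbers for fast clearance), so far:
- compound 1 `Cc1cc2c(cn1)Oc1ccc(NC(=O)c3ccc(Cl)cn3)cc1[C@@]21COC(N)=N1` gives < 14 mL.min-1.g-1 as a limit of the assay
- compound 2 `NC1=N[C@@]2(CO1)c1cc(-c3cncc(C#CCO)c3)ccc1Oc1cnc(C3=CCOCC3)cc12` gives 46 mL.min-1.g-1 as an exact number

Compound 1 sits at the limit of < 14 mL.min-1.g-1 in this assay, at which 1 of the 2 values shown sits, and so stands on a limit, not on a number. Compound 3 `NC1=N[C@@]2(CO1)c1cc(NC(=O)c3ccc(Cl)cn3)ccc1Oc1cnc(C3CCOCC3)cc12` has not yet been measured. It keeps the core of compound 1 and its amide side, with one change: oxan-4-yl in place of methyl on an aromatic carbon, next to the ring nitrogen. The count of that change reads oxan-4-yl in place of methyl on an aromatic carbon and it is the only difference between the two structures.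

Going by the values given here, no measured pair of compounds covers this change, so the expectation is a loose one. In this assay the estimated step of an at least 1.5-fold higher number from compound 1 to compound 3 (0.19 log units; that floor lies within the scatter) is expected to point upward, modestly beyond the scatter. Among the compounds with values here, that expectation leans on compound 2 at 46 mL.min-1.g-1 as the only exact number at hand. For compound 3 the estimate is 22 mL.min-1.g-1 with the reading expected between 12 mL.min-1.g-1 and 50 mL.min-1.g-1 as its range.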

Compound 3, intrinsic clearance in microsomes: 79 mL.min-1.g-1
Estimate against measurement, compound 3: 3.6-fold (0.56 log units) below; measured number above the stated range.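

On the aromatic carbon next to the ring nitrogen, with the shared core and the amide side kept, oxan-4-yl in place of methyl gives in this assay an at least 5.6-fold higher number from compound 1 to compound 3 (0.75 log units; beyond the scatter). Going by these compounds alone, this is the first change in one place that can be read at this position, and it shows that the read-out there is sensitive to the group carried: the larger ring moves the compound clearly towards fast clearance, a shift that compound 2, which differs from compound 1 in more than one place, could not isolate. The step is a floor and not an exact size, because compound 1 stands on a limit and not on a number: the limit of < 14 mL.min-1.g-1 in this assay, at which 1 of the 3 values shown sits.

The compounds shown leave open whether the step follows from the ring as such, from its oxygen or simply from the larger size of the group on this carbon. A cyclohexyl group, which keeps the ring without the oxygen, and an ethyl or methoxy group, which stay close to methyl, would tell these readings apart.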